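Amide Aryl Swap: Methyl Replaced by Nitro

A few compounds are considered here, and "the series" means these few. Any claim that something is new, unique, unknown or untested is made for them only; others in the source may bear on it.

compound 1 `O=C(Nc1ccccc1Cl)c1ccc(/N=N\c2c[nH]c3ccccc23)cc1` 120000 nM
compound 2 `Cc1ccc(C)c(NC(=O)c2ccc(/N=N\c3c[nH]c4ccccc34)cc2)c1` 544000 nM
compound 3 `Cc1ccccc1NC(=O)c1ccc(/N=N\c2c[nH]c3ccccc23)cc1` 509000 nM

Three measured compounds share one core and differ only in the aryl group on the amide-type nitrogen. In a functional assay on HCT-116 cells (Homo sapiens) for inhibition, read by MTT assay, with a stated time of 72 h (a higher number here means a weaker inhibitor, a lower number a stronger inhibitor), compound 1 gives 120000 nM, compound 2 gives 544000 nM and compound 3 gives 509000 nM. Compound 3 stands second highest of the three numbers: its nearest neighbour is compound 2 a 1.1-fold lower number from compound 2 to compound 3 (0.03 log units; within the scatter), its furthest is compound 1 a 4.2-fold higher number from compound 1 to compound 3 (0.63 log units; beyond the scatter).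

Compound 4 `O=C(Nc1ccc([N+](=O)[O-])cc1)c1ccc(/N=N\c2c[nH]c3ccccc23)cc1` has not yet been measured. The change from compound 3 is 4-nitrophenyl in place of 2-methylphenyl on an amide-type nitrogen. Among the measured compounds shown here, two measured steps touch this aryl group: a 4.2-fold higher number from compound 1 to compound 3 (0.63 log units; beyond the scatter) and a 4.5-fold higher number from compound 1 to compound 2 (0.66 log units; beyond the scatter). Both show that a changed substituent on this phenyl can move the number beyond the scatter, while a 1.1-fold lower number from compound 2 to compound 3 (0.03 log units; within the scatter) shows a second methyl mattering little. For the measured compounds named here, no measured compound carries a nitro group or a 4-substituted phenyl, so the direction rests on analogy alone. A modest lowering is expected, a 2.0-fold lower number from compound 3 to compound 4 (0.31 log units; beyond the scatter), giving an estimate for compound 4 of 250000 nM in this assay, within 80000 nM to 800000 nM.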

Compound 4, half-maximal inhibitory concentration: 156000 nM
Beside the measured number, compound 4's estimate is 1.6-fold (0.20 log units) above it, within the range that was stated.
By their numbers in this assay, from the lowest: compounds 1 and 4 (each within the scatter of the next); then compounds 3 and 2 (each within the scatter of the next).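

In this assay the 4-nitrophenyl group on the amide-type nitrogen lowers the number, with a 3.3-fold lower number from compound 3 to compound 4 (0.51 log units; beyond the scatter) and a 3.5-fold lower number from compound 2 to compound 4 (0.54 log units; beyond the scatter), so a chloro group is not the only substituent shown that sets a compound apart from the two methyl-bearing ones. The remaining step (a 1.3-fold higher number from compound 1 to compound 4 (0.11 log units; within the scatter)) shows that the 4-nitrophenyl and 2-chlorophenyl groups cannot be told apart here, even though they differ in substituent and in its place on the ring. No evidence is given that bears on why these two groups read alike.

The swap from 2-methylphenyl changes the substituent and its place together, and the compounds shown cannot separate the two. Going by these compounds, how an amine or a carboxylic acid on this phenyl would read also remains open.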